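The compounds below may be only part of what the source reports. "The series", "measured", "known", "first", "only" and "open" are said of these compounds alone.

Values in an ADME assay on Caco-2 cells (Homo sapiens) for permeability, in the apical to basolateral direction; on this read-out higher numbers stand for higher permeability and lower numbers for lower permeability:
- compound 1 `Cn1cncc1CN1CC(N(CC2CCN(C(=O)C(C)(C)C)CC2)S(=O)(=O)c2ccccn2)Cc2cc(C#N)ccc21`: 0.5 10^-6 cm/s
- compound 2 `Cn1cncc1CN1CC(N(CC2CCN(C(=O)c3ccc(Cl)cc3)CC2)S(=O)(=O)c2ccccn2)Cc2cc(C#N)ccc21`: 0.5 10^-6 cm/s
- compound 3 `Cn1cncc1CN1CC(N(CC2CCN(C(=O)C3CC3)CC2)S(=O)(=O)c2ccccn2)Cc2cc(C#N)ccc21`: 0.5 10^-6 cm/s

Compound 3 stands level with compound 1 and compound 2, so it sits neither at the top nor at the bottom of this small set. Compound 4 `C=C(C)C(=O)N1CCC(CN(C2Cc3cc(C#N)ccc3N(Cc3cncn3C)C2)S(=O)(=O)c2ccccn2)CC1` differs from it at one place: 1-methylethenyl in place of cyclopropyl on a carbonyl carbon. In words, this is 1-methylethenyl in place of cyclopropyl on a carbonyl carbon.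

Among the measured compounds shown here, all the measured steps bear on this same place: no change at the digits printed from compound 1 to compound 2 (within the scatter), no change at the digits printed from compound 1 to compound 3 (within the scatter) and no change at the digits printed from compound 2 to compound 3 (within the scatter). None of them moved this assay, so no shift beyond the scatter is expected, in either direction. The expected step is no change at the digits printed from compound 3 to compound 4 (within the scatter). For compound 4 the estimate is 0.5 10^-6 cm/s, with an expected range of 0.25 10^-6 cm/s to 1 10^-6 cm/s.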

Compound 4, apparent permeability: 0.5 10^-6 cm/s
Compound 4: the middle estimate sits on the measured number at the digits printed; measured number inside the range.
By their numbers in this assay, from the lowest: compounds 1, 2, 3 and 4 (each within the scatter of the next).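

In this assay, replacing the ring at this carbonyl carbon with an open group carrying a double bond gives no change at the digits printed from compound 3 to compound 4 (within the scatter). The same open group, set against the two other groups, gives no change at the digits printed from compound 2 to compound 4 (within the scatter) and no change at the digits printed from compound 1 to compound 4 (within the scatter). Among these four compounds, the read-out therefore stays level whether the group on this carbonyl carbon is a ring or open, and no data explaining this are available. Still open, as far as these compounds go, is whether an amine or a carboxylic acid on the group at this carbonyl carbon would leave this assay level as well.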